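A few compounds are considered here, and "the series" means these few. Any claim that something is new, unique, unknown or untested is made for them only; others in the source may bear on it.

Working notes on the series. Compound 1, `C=CC1=C(C(=O)Nc2ccccc2OC)C(c2ccc(F)cc2)OC1`, compound 2, `C=CC1=C(C(=O)Nc2ccccc2)C(c2ccc(F)cc2)OC1`, and compound 3, `C=CC1=C(C(=O)NC2CCCCC2)C(c2ccc(F)cc2)OC1`, share one core and differ only in the group on the amide-type nitrogen. In a functional assay on A549 cells (Homo sapiens) for cytotoxicity, read by MTT assay, with a stated time of 24 h (on this read-out lower numbers stand for stronger inhibition and higher numbers for weaker inhibition), compound 1 gives > 100000 nM, which is a limit of the assay and not a number. In this assay compound 2 gives > 100000 nM, again a limit. Compound 3 gives > 100000 nM in this assay, also a limit. The steps a step that the two limits leave unreadable from compound 1 to compound 2, a step that the two limits leave unreadable from compound 1 to compound 3 and a step that the two limits leave unreadable from compound 2 to compound 3 therefore carry no readable size because of the limit of > 100000 nM in this assay, at which 3 of the 3 values shown sit.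

Compound 4, `C=CC1=C(C(=O)NCC(C)C)C(c2ccc(F)cc2)OC1`, is not yet measured in this assay. Its difference from compound 3: isobutyl in place of cyclohexyl on an amide-type nitrogen. For the measured compounds named here, the steps that bear on this change are those at the same amide-type nitrogen, from compound 1 and from compound 2 to compound 3, and both are unreadable in size, so no direction and no size beyond the scatter can be expected from them. Compound 4 is therefore expected to give a value near the limit again, estimated at 150000 nM with a range from 50000 nM to 500000 nM. The step this estimate means is a step that the limit leaves unreadable from compound 3 to compound 4, and it is expected to remain unreadable.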

Compound 4, half-maximal inhibitory concentration: > 100000 nM
Compound 4 gave a limit, no number; the forecaster's own chance of this, stated with the estimate: 85%; the middle value is on the limit's open side.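

Compound 4 adds no readable step: its steps from compound 1, compound 2 and compound 3 in this assay cannot be read, and the values of all these compounds are limits, not numbers: the limit of > 100000 nM in this assay, at which 4 of the 4 values shown sit.

The compounds shown leave open whether any group on the amide-type nitrogen, or any change elsewhere on the shared core, would give a numerical value in this assay.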